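The source may report more compounds than this note shows. Statements on the series, on what has been measured and on what is new or still open speak of the compounds shown alone.

Compound 1 `Cc1n[nH]c(-c2ccccc2NCC2=NCCN2)n1` gives 0% in a functional assay with Alpha-1B adrenergic receptor (Homo sapiens) as the target, read by calcium flux; on this read-out lower numbers stand for smaller maximal responses and higher numbers for larger maximal responses. Compound 2 `Cn1ncnc1-c1ccccc1NCC1=NCCN1` gives 93%.

Among the compounds with values here, compound 2 stands highest of the two numbers measured so far; its nearest neighbour is compound 1, reached by a number 93 percentage points higher from compound 1 to compound 2 (beyond the scatter). Compound 3 `c1ccc(-c2cn[nH]c2)c(NCC2=NCCN2)c1` is not yet measured. It differs from compound 2 by 1H-pyrazol-4-yl in place of 1-methyl-1H-1,2,4-triazol-5-yl on an aromatic carbon. Within the data shown here, the only measured step, that from compound 1 to compound 2, changes the same ring at the same place and is large, so a change at this position can move the maximal response strongly in either direction. The size and direction of the step for compound 3 are therefore uncertain; a step of a number 48 percentage points lower from compound 2 to compound 3 (beyond the scatter) is expected, and compound 3 is estimated at 45%, with a range from 5% to 95%.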

Compound 3, largest response reached (reported as maximal response), in percent of the reference or control that the assay uses: 72%
Compound 3: middle estimate off by 27 percentage points, on the low side; the range from low to high includes it.
By their numbers in this assay, from the lowest: compound 1; then compound 3; then compound 2.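

In this assay the 1H-pyrazol-4-yl group brings only a modest loss, with a number 21 percentage points lower from compound 2 to compound 3 (beyond the scatter), yet a large gain over the 3-methyl-1H-1,2,4-triazol-5-yl group, with a number 72 percentage points higher from compound 1 to compound 3 (beyond the scatter). A high response at this place therefore does not depend on the 1-methyl-1H-1,2,4-triazol-5-yl group, since a ring with 2 hetero atoms and 1 hydrogen-bond donor also gives one. Nothing at hand explains these differences.

The compounds shown leave open whether a methyl on the ring nitrogen of the 1H-pyrazol-4-yl group would change the response. They also leave open what a group other than a five-membered aromatic ring, such as an amine or a carboxylic acid, would give at this place.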